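The source may report more compounds than this note shows. Statements on the series, on what has been measured and on what is new or still open speak of the compounds shown alone.

Measured so far in a functional assay on LN-229 cells (Homo sapiens) for antiproliferative activity, with a stated time of 72 h; on this read-out higher numbers stand for weaker inhibition and lower numbers for stronger inhibition:
- compound 1 `CCCCC#Cc1cc([C@@H]2O[C@H](CO)[C@@H](O)[C@H]2O)n2ncnc(N)c12` gives 1000 nM
- compound 2 `Nc1ncnn2c([C@@H]3O[C@H](CO)[C@@H](O)[C@H]3O)cc(/C=C/c3ccccc3)c12` gives 3900 nM

Compound 2 has the higher of these two numbers, so it is the weaker inhibitor of the pair. Compound 3 (`Nc1ncnn2c([C@@H]3O[C@H](CO)[C@@H](O)[C@H]3O)cc(-c3ccccc3Cl)c12`) has not yet been measured. It carries 2-chlorophenyl in place of 2-phenylethenyl on an aromatic carbon. For the measured compounds named here, only one measured step changes this same place: a 3.9-fold higher number from compound 1 to compound 2 (0.59 log units; beyond the scatter), a modest change beyond the scatter, with 2-phenylethenyl replacing hex-1-yn-1-yl. Going by the values given here, it shows that the group here can shift the number, but no measured compound has a ring attached directly at this place, so the direction stays open. A change of similar or smaller size is therefore expected in this assay, possibly none beyond the scatter. The estimated step is a 1.3-fold lower number from compound 2 to compound 3 (0.11 log units; within the scatter) here. For compound 3 the expected value is 3000 nM, with an estimated range from 800 nM to 10000 nM.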

Compound 3, half-maximal inhibitory concentration: > 100000 nM
Compound 3: a limit, no number; the forecaster's own chance of this, stated with the estimate: 15%; middle value at least 33-fold (1.52 log units) from the limit.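

For compound 3, the result in this assay is a limit and not a number: the limit of > 100000 nM in this assay, at which 1 of the 3 values shown sits.

Placing 2-chlorophenyl at this aromatic carbon gives an at least 25-fold higher number from compound 2 to compound 3 (1.40 log units; beyond the scatter), and the same place gives an at least 100-fold higher number from compound 1 to compound 3 (2.00 log units; beyond the scatter). The earlier step between hex-1-yn-1-yl and 2-phenylethenyl was modest, so these steps show that this position can respond far more strongly than that step alone revealed, and that the direction for this change is towards weaker inhibition.

The compounds shown cannot tell whether this large change goes with the ring attached directly to the core or with the chlorine on that ring, a question that plain phenyl at this place would address. As far as these compounds go, how an amine or a saturated chain such as hexyl would read at this position also remains open.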